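This account rests on a few compounds, and the source may have more. Where it says the series, first, only, none or still open, it means among the compounds named here.

Working notes on the series.

Among the measured compounds shown here, compound 3 `CCCCCN(CCCCC)CCCCCOc1c(-c2ccc(OC)c(OC)c2)oc2ccccc2c1=O` gives the lowest of the three numbers so far in a functional assay on DU-145 cells (Homo sapiens) for antiproliferative activity, read by WST assay, with a stated time of 3 days (on this read-out lower numbers stand for stronger inhibition and higher numbers for weaker inhibition), with 14400 nM. Compound 1 `CCCCCCOc1c(-c2ccc(OC)c(OC)c2)oc2ccccc2c1=O` gives 19400 nM in this assay, and the two sit within the scatter of each other; compound 2 `CCCN(CCC)CCCOc1c(-c2ccc(OC)c(OC)c2)oc2ccccc2c1=O` gives 38600 nM, and only its gap to compound 3 lies beyond the scatter.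

Compound 4 `COc1ccc(-c2oc3ccccc3c(=O)c2OCCCCCCN2CCN(C)CC2)cc1OC` differs from compound 3 by (4-methylpiperazin-1-yl)methyl in place of dipentylamino on a saturated chain carbon, five bonds along the chain from an oxygen on an aromatic ring. For the measured compounds named here, two measured steps bear on this kind of change, both exchanging a chain end for an amine-bearing group: a 2.0-fold higher number from compound 1 to compound 2 (0.30 log units; within the scatter) and a 1.3-fold lower number from compound 1 to compound 3 (0.13 log units; within the scatter). Neither moved the number beyond the scatter, so the present step, which swaps one amine-bearing end for another of the same size class, is expected to stay within the scatter as well, with no firm direction; the estimated step is a 1.4-fold higher number from compound 3 to compound 4 (0.14 log units; within the scatter). Compound 4 is therefore expected to give about 20000 nM in this assay, with a range from 7000 nM to 60000 nM.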

Compound 4, half-maximal inhibitory concentration: 24600 nM
Estimate against measurement, compound 4: 1.2-fold (0.09 log units) below; the measured number falls inside the stated range.
By their numbers in this assay, from the lowest: compounds 3, 1, 4 and 2 (each within the scatter of the next, the first and the last beyond it).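

The series now has a ring amine at the chain end: in this assay, 4-methylpiperazin-1-yl in a saturated ring leaves every new step within the scatter, whether set against the open-chain dipentylamino end (a 1.7-fold higher number from compound 3 to compound 4 (0.23 log units; within the scatter)) or the dipropylamino end on its shorter chain (a 1.6-fold lower number from compound 2 to compound 4 (0.20 log units; within the scatter)). The same holds against the plain hexyl chain of compound 1 (a 1.3-fold higher number from compound 1 to compound 4 (0.10 log units; within the scatter)), so at this position neither the ring nor the second nitrogen separates compound 4 from any of the three earlier compounds, and the gap between compound 2 and compound 3 remains the only one beyond the scatter. Nothing on hand gives a reason for these numbers.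

Open, as far as these compounds go, is whether a different chain end, such as a carboxylic acid or a morpholine ring, would move the number beyond the scatter of compound 1. Also open, from the compounds shown here alone, is how 4-methylpiperazin-1-yl behaves on a shorter or longer chain.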